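The source may report more compounds than this note shows. Statements on the series, on what has been measured and on what is new or still open speak of the compounds shown alone.

Measured compounds:
- compound 1, `Clc1ccc(-c2nnc(COc3ccc(-c4ccccc4)cc3)o2)cc1`: 75%
- compound 2, `CCCCNc1nnc(COc2ccc(-c3ccccc3)cc2)s1`: 27.3%

In a functional assay on the whole organism (strain Wistar) for inhibition, with Rattus norvegicus as the target, read by paw edema, with a stated time of 3 h, at a dose of 10 mg/kg by the oral route (on this read-out lower numbers stand for less inhibition and higher numbers for more inhibition at the one dose given (going by the name of the read-out)), compound 1 gives 75%. In this assay compound 2 gives 27.3%, the lowest of the two numbers, and it lies a long way under compound 1, beyond the scatter. Compound 3, `Fc1ccc(Nc2nnc(COc3ccc(-c4ccccc4)cc3)s2)cc1`, is not yet measured. It differs from compound 2 in one place: 4-fluorophenyl in place of butyl on a nitrogen on an aromatic ring. Among the compounds with values here, no step between two measured compounds follows this exact change, so the size of the step in this assay is not fixed by the data. Compound 1, which carries an aromatic ring in place of a chain at the corresponding end of its core, stands well above compound 2, which gives some ground for expecting compound 3 to rise rather than fall. The step from compound 2 to compound 3 is expected to be a number 20.7 percentage points higher from compound 2 to compound 3 (beyond the scatter). Compound 3 is estimated at 48%, within a range from 22% to 72%.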

Compound 3, a percentage reported as inhibition, in the whole organism at one dose (the size of the read-out at that dose, not a potency): 27.3%
For compound 3 the middle estimate is 20.7 percentage points above the measured one; the range from low to high includes it.
By their numbers in this assay, from the lowest: compounds 2 and 3 (each within the scatter of the next); then compound 1.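

In this assay, 4-fluorophenyl in place of butyl on a nitrogen on an aromatic ring gives no change at the digits printed from compound 2 to compound 3 (within the scatter). At this place and this one dose, then, a chain and a six-membered aromatic ring of carbon only read alike, and putting a ring on this nitrogen does not by itself separate the two compounds. No measurement shown accounts for this sameness.

What the compounds leave open is whether any group on this nitrogen moves the read-out, for instance a longer chain such as octyl, or a phenyl ring carrying a carboxylic acid. Also open, on these data alone, is what separates compound 1 from the other two, as it differs from each of them in more than one place.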